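One Ring Swap at a Carbonyl Carbon

A few compounds are considered here, and "the series" means these few. Any claim that something is new, unique, unknown or untested is made for them only; others in the source may bear on it.

Three amides sharing one core have been tested in a functional assay on A2780 cells (Homo sapiens) for inhibition, read by sulforhodamine B assay, with a stated time of 72 h; on this read-out higher numbers stand for weaker inhibition and lower numbers for stronger inhibition. Within the data shown here, compound 1 (`O=C(NCc1ccc(S(=O)(=O)N2CCCCC2)cc1)c1cc2cnccc2s1`) gives 1600 nM, the only actual number of the set. Compound 2 (`O=C(NCc1ccc(S(=O)(=O)N2CCCCC2)cc1)c1ccn2ccnc2c1`) reads > 10000 nM, which is a limit of the assay and not a number. Compound 3 (`O=C(NCc1ccc(S(=O)(=O)N2CCCCC2)cc1)c1cc2cccnc2s1`) reads > 10000 nM, again only a limit, so it stands at the weak end of the readings so far.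

The next compound is compound 4 (`O=C(NCc1ccc(S(=O)(=O)N2CCCCC2)cc1)c1ccn2cncc2c1`), and the structural change is a group of 9 heavy atoms (7 carbon, 2 nitrogen; one five-membered aromatic ring with 2 hetero atoms, one six-membered aromatic ring with 1 hetero atom) in place of a group of 9 heavy atoms (7 carbon, 1 nitrogen, 1 sulfur; one five-membered aromatic ring with 1 hetero atom, one six-membered aromatic ring with 1 hetero atom), on a carbonyl carbon. Among the measured compounds shown here, two measured steps bear on it. One is an at least 6.2-fold higher number from compound 1 to compound 3 (0.79 log units; beyond the scatter), and the other is an at least 6.2-fold higher number from compound 1 to compound 2 (0.79 log units; beyond the scatter). Both lie beyond the scatter, so neither replacement of the group in compound 1 kept its strength. The step that the two limits leave unreadable from compound 2 to compound 3 cannot be sized.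

For the measured compounds named here, the group entering here matches in its counts the one in the step of an at least 6.2-fold higher number from compound 1 to compound 2 (0.79 log units; beyond the scatter), so a weak result is expected, and another limit reading is quite possible. Still, 1600 nM for compound 1 shows that a measurable number is within reach for a group of this size. The expected change is small, with an estimated at least 1.6-fold lower number from compound 3 to compound 4 (0.22 log units; that floor lies within the scatter). Compound 4 is expected at about 6000 nM, with an estimated range of 1500 nM to 20000 nM.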

Compound 4, half-maximal inhibitory concentration: > 10000 nM
Compound 4: only a limit was reported; the forecaster's own chance of this, stated with the estimate: 50%; at least 1.6-fold (0.22 log units) between middle value and limit.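

In this assay, the ring swap on the carbonyl carbon gives an at least 6.2-fold higher number from compound 1 to compound 4 (0.79 log units; beyond the scatter), which makes this the third replacement of that group to fall short of the strength of the original. Compound 2 and compound 4 carry groups with identical counts of atoms and rings, and neither of these two arrangements gives a measurable number in this assay. The steps among compound 2, compound 3 and compound 4 cannot be read, so no order can be given among the three, whose readings all stop at the same limit: the limit of > 10000 nM in this assay, at which 3 of the 4 values shown sit.

Compound 1 remains the only compound with an actual number, so the compounds shown cannot tell how far past the limit the other three lie, or which feature of the group in compound 1 carries its strength. Also open, from the compounds shown here alone, is whether an amine or a carboxylic acid added to the group in compound 1 would keep that strength, improve it or lose it.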